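Working notes: amino in place of chloro

A few compounds are considered here, and "the series" means these few. Any claim that something is new, unique, unknown or untested is made for them only; others in the source may bear on it.

Measured in a functional assay on MT4 cells (Homo sapiens) for inhibition; a higher number here means a weaker inhibitor, a lower number a stronger inhibitor:
- compound 1 `C=C1C(n2ccc(N)nc2=O)O[C@H](CO)[C@@H]1O` (190 nM)
- compound 2 `C=C1[C@@H](O)[C@H](n2cnc3c(O)nc(N)nc32)O[C@@H]1CO` (a limit, > 200000 nM)
- compound 3 `C=C1[C@H](n2cnc3c(Cl)nc(N)nc32)O[C@H](CO)[C@H]1O` (176000 nM)

The reading for compound 2 (> 200000 nM) is a limit. Compound 3 (176000 nM) holds the higher of the two actual numbers, and compound 1 (190 nM) lies far below it, beyond the scatter.

Compound 4 `C=C1[C@H](n2cnc3c(N)nc(N)nc32)O[C@H](CO)[C@H]1O` is unmeasured. Relative to compound 3 it has amino in place of chloro on an aromatic carbon. For the measured compounds named here, no measured pair shows this change alone. A moderate move toward a lower number in this assay is expected, beyond the scatter, with compound 4 still far from compound 1 (190 nM). The expected step is a 4.4-fold lower number from compound 3 to compound 4 (0.64 log units; beyond the scatter) as estimated. For compound 4 the estimated value is 40000 nM within an expected range from 5000 nM to 200000 nM as a working figure.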

Compound 4, half-maximal inhibitory concentration: > 500000 nM
Compound 4 ended at the assay's limit; the forecaster's own chance of this, stated with the estimate: 25%; middle value at least 12-fold (1.09 log units) from the limit.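

Amino in place of chloro on this aromatic carbon brings no gain: the change gives an at least 2.8-fold higher number from compound 3 to compound 4 (0.45 log units; beyond the scatter) in this assay, so of these two groups chloro gives the lower number at this position. The size of this step has only a lower bound. The reading for compound 4 is a limit, not a number: the limit of > 500000 nM in this assay, at which 1 of the 4 values shown sits.

Going by these compounds, whether methoxy or a methylamino group at this position would give a lower number than compound 3 remains open. For the compounds shown here, this is the only pair showing the change, so its effect on any other core is also unknown.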